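Removing the trifluoromethoxy group from compound 1

This account rests on a few compounds, and the source may have more. Where it says the series, first, only, none or still open, it means among the compounds named here.

Measured compounds in a functional assay on HL-60 cells (Homo sapiens) for cytotoxicity, read by luminescence and CellTiter-Glo, with a stated time of 3 days; on this read-out higher numbers stand for weaker inhibition and lower numbers for stronger inhibition:
compound 1 `O=C(Nc1ccc(OC(F)(F)F)cc1)c1cc(F)ccc1O` gives 850 nM
compound 2 `N#Cc1ccc(NC(=O)c2ccc3cccnc3c2O)c(Cl)c1` gives 910 nM
compound 3 `O=C(Nc1ccc(C(F)(F)F)cc1)c1ccc(F)cc1O` gives 680 nM

Compound 1 stands at the second highest of the three numbers, but the three lie close together. Its nearest neighbour is compound 2, whose number is only slightly higher and within the usual scatter; the furthest is compound 3, whose number is somewhat lower and also within the scatter. Among the compounds with values here, none of the measured compounds differ from one another in a single place, so no measured step is available to lean on.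

The unmeasured compound is compound 4 `O=C(Nc1ccccc1)c1cc(F)ccc1O`. It differs from compound 1 by hydrogen in place of trifluoromethoxy on an aromatic carbon. The change removes a group and puts only a hydrogen in its place, and the measured set gives no guidance on what such a removal does here. In this assay the step from compound 1 to compound 4 is expected to be a 2.9-fold higher number from compound 1 to compound 4 (0.47 log units; beyond the scatter), towards a higher number, probably a little beyond the scatter. Compound 4 is therefore expected to give about 2500 nM, with a range from 900 nM to 7000 nM.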

Compound 4, half-maximal inhibitory concentration: > 10000 nM
Compound 4 gave a limit, no number (the forecaster's own chance of this, stated with the estimate: 10%); middle value at least 4.0-fold (0.60 log units) from the limit.
By their numbers in this assay, from the lowest: compounds 3, 1 and 2 (each within the scatter of the next). At a limit, above all of these: compound 4.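

In this assay the series now has its first comparison in a single place, and hydrogen in place of trifluoromethoxy on an aromatic carbon is a large step: an at least 11-fold higher number from compound 1 to compound 4 (1.07 log units; beyond the scatter). Compound 4 gives > 10000 nM, which is a limit of the assay and not a number. On the core of compound 1, the group at this position therefore carries a large part of the measured value, and the step is bounded on one side only: the limit of > 10000 nM in this assay, at which 1 of the 4 values shown sits.

Open, on these data alone, is whether another group here, such as methoxy, chlorine or an amine, would keep a value close to that of compound 1, or whether this holds only for trifluoromethoxy. Also open, as far as these compounds go, is whether hydrogen in place of the trifluoromethyl group of compound 3 would give a step of similar size.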